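Varying the Aryl Group on a Growth-Inactive Series

The source may report more compounds than this note shows. Statements on the series, on what has been measured and on what is new or still open speak of the compounds shown alone.

Of the compounds shown here, two have been measured so far. Compound 1 `COc1ccc(Nc2ncc(C(F)(F)F)c(N3Cc4cccc(N(C)S(C)(=O)=O)c4C3)n2)cc1C(F)(F)F` carries a 4-methoxy-3-(trifluoromethyl)phenyl group, and in a functional assay on HepG2 cells (Homo sapiens) for antiproliferative activity, read by spectrophotometry, with a stated time of 2 days (on this read-out lower numbers stand for stronger inhibition of growth and higher numbers for weaker inhibition of growth), compound 1 gives > 30000 nM, which is a limit of the assay and not a number. Compound 2 `CN(c1cccc2c1CN(c1nc(Nc3ccc(C(F)(F)F)cc3)ncc1C(F)(F)F)C2)S(C)(=O)=O` differs only in that aryl group, and in this assay compound 2 gives > 30000 nM, again a limit rather than a number. Among the measured compounds shown here, the step that the two limits leave unreadable from compound 1 to compound 2 therefore cannot be read, and compound 2 stands only at a limit, as does the one further value shown. Both results sit at the limit of > 30000 nM in this assay, at which 2 of the 2 values shown sit.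

Compound 3 `COc1cc(Nc2ncc(C(F)(F)F)c(N3Cc4cccc(N(C)S(C)(=O)=O)c4C3)n2)cc(C(F)(F)F)c1` is not yet measured. Its change from compound 2 is 3-methoxy-5-(trifluoromethyl)phenyl in place of 4-(trifluoromethyl)phenyl on a nitrogen on an aromatic ring. For the measured compounds named here, only the step from compound 1 to compound 2 bears on such a change of the aryl group, and its size is not readable. No step beyond the scatter is known, so no shift beyond the scatter is expected in this assay from this substitution. Compound 3 is therefore expected to give 40000 nM in this assay, with a range from 15000 nM to 100000 nM, most likely again as a limit. The expected step is a step that the limit leaves unreadable from compound 2 to compound 3.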

Compound 3, concentration for 50% growth inhibition: 22100 nM
Compound 3: the middle estimate sits 1.8-fold (0.26 log units) above what was measured, within the range that was stated.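

In this assay, among the compounds shown here, the 3-methoxy-5-(trifluoromethyl)phenyl group on this nitrogen gives the only value among the three compounds that is a number and not a limit, so the change of aryl group can now be given a floor: the exchange for 4-(trifluoromethyl)phenyl is an at least 1.3-fold lower number from compound 2 to compound 3 (0.13 log units; that floor lies within the scatter). The exchange for 4-methoxy-3-(trifluoromethyl)phenyl reads the same way, as an at least 1.3-fold lower number from compound 1 to compound 3 (0.13 log units; that floor lies within the scatter), so neither floor yet shows that the aryl group at this position moves growth inhibition beyond the scatter. The step between the two other compounds still cannot be read, since both remain at a limit of the assay: the limit of > 30000 nM in this assay, at which 2 of the 3 values shown sit.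

From the compounds shown here alone, how large the two readable steps truly are stays open, as does whether any aryl group on this nitrogen can bring the value of the series clearly down from that of compound 3. Also open, going by these compounds, is what a morpholine or a carboxylic acid in place of the methoxy group of compound 3 would give in this assay.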